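The compounds below may be only part of what the source reports. "The series", "measured", "known", "first", "only" and "open" are said of these compounds alone.

Measured compounds in an ADME assay on BJ cells (Homo sapiens) for cytotoxicity, read by CellTiter-Glo and resazurin assay, with a stated time of 72 h; a higher number here means that more compound is needed for the effect, a lower number that less compound is needed:
- compound 1, `CC(C)N(Cc1cccc(OCCCCCC(=O)O)c1)C(=O)c1ccc(-c2ccncc2)cc1`; compound 1 gives > 26000 nM, a limit of the assay, not a number.
- compound 2, `CC(C)N(Cc1cccc(OCCCCCC(=O)O)c1)C(=O)c1ccc(-c2cccc(O)c2)cc1`; compound 2 gives > 26000 nM, again a limit.
- compound 3, `CCOC(=O)CCCCCOc1cccc(CN(C(=O)c2ccc(-c3ccncc3)cc2)C(C)C)c1`; compound 3 gives > 26000 nM, also a limit.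

For the measured compounds named here, compound 3 therefore stands on a limit only, and the two other values shown in this assay are limits as well; no compound has yet given a readable number. The two measured steps that touch compound 3 or its close relatives are a step that the two limits leave unreadable from compound 1 to compound 2 and a step that the two limits leave unreadable from compound 1 to compound 3, and both are left unreadable by the limits, so they give no size and no direction. What the set does show is the limit of > 26000 nM in this assay, at which 3 of the 3 values shown sit.

Compound 4 is `CCOC(=O)CCCCCOc1cccc(CN(C(=O)c2ccc(-c3cccc(OCC)c3)cc2)C(C)C)c1`. It differs from compound 3 as follows: 3-ethoxyphenyl in place of pyridin-4-yl on an aromatic carbon. Going by the values given here, because the limit of > 26000 nM in this assay, at which 3 of the 3 values shown sit, holds for every compound measured so far, including the two nearest relatives of compound 4, the step that the limit leaves unreadable from compound 3 to compound 4 is expected to leave compound 4 at the same limit rather than yield a readable number. Compound 4 is therefore estimated at 30000 nM in this assay, with a range from 12000 nM to 80000 nM, and most likely only a limit will be reported.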

Compound 4, half-maximal effective concentration: > 22300 nM
Compound 4: no number, only a limit; the forecaster's own chance of this, stated with the estimate: 85%; the middle value lies beyond the limit too.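

In this assay, compound 3 and compound 4 both give only limits of the assay, not numbers, so the step between them cannot be read. The compounds shown leave open at what concentration any of them reaches the half-maximal effect, and whether 3-ethoxyphenyl in place of pyridin-4-yl changes that concentration at all.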